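This account rests on a few compounds, and the source may have more. Where it says the series, first, only, none or still open, it means among the compounds named here.

Compound 1 `COc1ccccc1-c1ccccc1O` is weak in a functional assay on MCF7 cells (Homo sapiens) for cytotoxicity, read by MTT assay, with a stated time of 3 days; a lower number here means a stronger inhibitor, a higher number a weaker inhibitor. In this assay compound 1 gives > 100 ug/mL, which is a limit of the assay and not a number (the limit of > 100 ug/mL in this assay, at which 1 of the 2 values shown sits). Compound 2 `Nc1ccccc1-c1ccccc1O` gives 56 ug/mL in this assay. Among the compounds with values here, the only measured step, an at least 1.7-fold lower number from compound 1 to compound 2 (0.25 log units; that floor lies within the scatter), concerns amino in place of methoxy and so does not bear on adding a methoxy group. Compound 3 `COc1ccc(-c2ccccc2O)c(OC)c1` differs from compound 1 by methoxy in place of hydrogen on an aromatic carbon. Within the data shown here, with no measured step of this kind, no change beyond the scatter is expected. Compound 3 is therefore estimated at 100 ug/mL, between 40 ug/mL and 250 ug/mL. The step this expectation means, a number no higher from compound 1 to compound 3 (the limit leaves the size open), is expected to stay within the scatter.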

Compound 3, half-maximal inhibitory concentration: > 100 ug/mL
Compound 3 was reported as a limit; the forecaster's own chance of this, stated with the estimate: 60%; the middle value lies on the limit itself.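

Compound 1 and compound 3 both stand at a limit of this assay and not at a number, so no step between them can be read: the limit of > 100 ug/mL in this assay, at which 2 of the 3 values shown sit.

From the compounds shown here alone, what methoxy in place of hydrogen on an aromatic carbon does to the number in this assay stays open.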